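Thiophen-2-yl in place of furan-2-yl

The source may hold more compounds than are shown below. What is called first, only, known or untested is meant among the compounds shown, and "the series" means these compounds.

In a functional assay on THP-1 cells (Homo sapiens) for inhibition, read by sulforhodamine B assay, with a stated time of 48 h, tested at 50 uM (a higher number here means more inhibition of growth at the concentration tested, a lower number less inhibition of growth), compound 1 (`COc1cc(/C=C/C(=O)/C=C/c2ccco2)ccc1OCc1cn(CCCOc2cc(=O)oc3ccccc23)nn1`) gives 57%, the highest of the three numbers available. Compound 2 (`COc1cc(/C=C/C(=O)/C=C/c2ccccc2)ccc1OCc1cn(CCCCOc2cc(=O)oc3ccccc23)nn1`) gives 36%, and compound 3 (`COc1cc(/C=C/C(=O)/C=C/c2ccccc2)ccc1OCc1cn(CCCCCOc2cc(=O)oc3ccccc23)nn1`) gives 26%. Both of these numbers lie below that of compound 1, beyond the scatter. Among the measured compounds shown here, no step between these three compounds that isolates a change in one place has been measured, so they offer no direct guide to the next comparison.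

Compound 4 (`COc1cc(/C=C/C(=O)/C=C/c2cccs2)ccc1OCc1cn(CCCOc2cc(=O)oc3ccccc23)nn1`) differs from compound 1 in one place: thiophen-2-yl in place of furan-2-yl on a double-bonded chain carbon bound to a double-bonded chain carbon, with thiophen-2-yl in place of furan-2-yl on a double-bonded chain carbon bound to a double-bonded chain carbon. The two groups match in everything counted except the hetero atom, so no step beyond the scatter is expected in this assay. That expectation starts from compound 1 at 57%. The estimated change is a number 4 percentage points lower from compound 1 to compound 4 (within the scatter). For compound 4 the expected value is 53%, with an estimated range of 38% to 68%.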

Compound 4, percent growth inhibition at one concentration: 54%
For compound 4 the middle estimate is 1 percentage points below the measured one; low and high end bracket the measured number.
By their numbers in this assay, from the lowest: compounds 3 and 2 (each within the scatter of the next); then compounds 4 and 1 (each within the scatter of the next).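

Among the compounds shown here, exchanging furan-2-yl for thiophen-2-yl on a double-bonded chain carbon bound to a double-bonded chain carbon gives a number 3 percentage points lower from compound 1 to compound 4 (within the scatter) in this assay and so provides the first comparison in this set that isolates a change in one place. It shows that, at this position and in this read-out, sulfur can stand in place of oxygen in the five-membered aromatic ring without a step beyond the scatter. No measurement at hand bears on why the two groups read alike.

From the compounds shown here alone, whether a pyridin-2-yl group, or a furan-2-yl carrying an amine, would read alike at this position stays open. The compounds shown also do not separate the part played by this ring from that of the chain, since compound 2 and compound 3 differ from compound 1 in more than one place.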